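This account rests on a few compounds, and the source may have more. Where it says the series, first, only, none or still open, it means among the compounds named here.

In a functional assay on NCI-H460 cells (Homo sapiens) for cytotoxicity, read by MTT assay, with a stated time of 72 h (on this read-out higher numbers stand for weaker inhibition and lower numbers for stronger inhibition), compound 3 `CN(C)CCn1cnnc1-c1cc(Oc2ccc(NC(=O)N/N=C/c3ccccc3)cc2F)ccn1` gives 1780 nM, the highest of the three numbers shown, although each gap to the others stays within the scatter: compound 1 `CN(C)CCn1cnnc1-c1cc(Oc2ccc(NC(=O)N/N=C/c3c[nH]c4ccccc34)cc2F)ccn1` gives 1630 nM, and compound 2 `CN(C)CCn1cnnc1-c1cc(Oc2ccc(NC(=O)N/N=C/c3ccccc3O[N+](=O)[O-])cc2F)ccn1` gives 1270 nM. The steps of a 1.1-fold higher number from compound 1 to compound 3 (0.04 log units; within the scatter) and a 1.4-fold higher number from compound 2 to compound 3 (0.15 log units; within the scatter) are both within the scatter, as is a 1.3-fold lower number from compound 1 to compound 2 (0.11 log units; within the scatter). Compound 4 `CN(C)CCn1cnnc1-c1cc(Oc2ccc(NC(=O)N/N=C/c3ccc(F)cc3)cc2F)ccn1` differs from compound 3 by fluoro in place of hydrogen on an aromatic carbon. The step that bears most directly on this change is the earlier exchange of a group on an aromatic carbon, a 1.4-fold higher number from compound 2 to compound 3 (0.15 log units; within the scatter), and the exchange of the whole ring, a 1.1-fold higher number from compound 1 to compound 3 (0.04 log units; within the scatter); no step beyond the scatter is expected in this assay because a 1.4-fold higher number from compound 2 to compound 3 (0.15 log units; within the scatter) was small. Compound 4 is therefore expected to give 1700 nM, between 850 nM and 3400 nM, which is estimated as a 1.0-fold lower number from compound 3 to compound 4 (0.02 log units; within the scatter).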

Compound 4, half-maximal inhibitory concentration: 1980 nM
Beside the measured number, compound 4's estimate is 1.2-fold (0.07 log units) below it; the range from low to high includes it.
By their numbers in this assay, from the lowest: compounds 2, 1, 3 and 4 (each within the scatter of the next).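

In this assay, fluoro on the aromatic carbon para to a large group gives a 1.1-fold higher number from compound 3 to compound 4 (0.05 log units; within the scatter), so this position tolerates a halogen in place of hydrogen without a step beyond the scatter. The 4-fluorophenyl group also stays within the scatter of the other two groups at this end of the molecule, with a 1.6-fold higher number from compound 2 to compound 4 (0.19 log units; within the scatter) and a 1.2-fold higher number from compound 1 to compound 4 (0.08 log units; within the scatter). No exchange among these four compounds has yet moved the number beyond the scatter.

Nothing available explains this result. From the compounds shown here alone, whether an amine or a carboxylic acid on that aromatic carbon would move the number beyond the scatter remains open.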